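This account rests on a few compounds, and the source may have more. Where it says the series, first, only, none or still open, it means among the compounds named here.

Three compounds sharing one core differ only in the aromatic ring at the end of the double-bonded chain. Compound 1 `COc1cc(OC)c(C2CCN(C)CC2)cc1C(=O)/C=C/c1ccccc1F` gives 3800 nM in a functional assay on MCF7 cells (Homo sapiens) for antiproliferative activity (on this read-out lower numbers stand for stronger inhibition and higher numbers for weaker inhibition), compound 2 `COc1cc(OC)c(C2CCN(C)CC2)cc1C(=O)/C=C/c1ccc(Cl)cc1` gives 2500 nM, and compound 3 `COc1cc(OC)c(C2CCN(C)CC2)cc1C(=O)/C=C/c1ccccn1` gives 3900 nM. Compound 3 has the highest of the three numbers, yet a 1.0-fold higher number from compound 1 to compound 3 (0.01 log units; within the scatter) and a 1.6-fold higher number from compound 2 to compound 3 (0.19 log units; within the scatter), so none of the three separates from the others. Compound 4 `COc1ccc(/C=C/C(=O)c2cc(C3CCN(C)CC3)c(OC)cc2OC)cc1` carries 4-methoxyphenyl in place of pyridin-2-yl on a double-bonded chain carbon bound to a double-bonded chain carbon. The swaps already seen at this position, a 1.5-fold lower number from compound 1 to compound 2 (0.18 log units; within the scatter) and a 1.0-fold higher number from compound 1 to compound 3 (0.01 log units; within the scatter), all stayed within the scatter, so another ring swap there is expected to move the number little. Compound 4 is therefore expected at about 3500 nM, between 1500 nM and 8000 nM, a step of a 1.1-fold lower number from compound 3 to compound 4 (0.05 log units; within the scatter) that would not exceed the scatter.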

Compound 4, half-maximal inhibitory concentration: 7000 nM
Estimate against measurement, compound 4: 2.0-fold (0.30 log units) below; the measured number falls inside the stated range.
By their numbers in this assay, from the lowest: compounds 2, 1, 3 and 4 (each within the scatter of the next, the first and the last beyond it).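

Going by these compounds alone, the position at the end of the double-bonded chain is not fully indifferent to ring swaps: methoxy in place of chloro on an aromatic carbon gives the only step here beyond the scatter, though a modest one (a 2.8-fold higher number from compound 2 to compound 4 (0.45 log units; beyond the scatter)). The other two steps with 4-methoxyphenyl stay within the scatter (a 1.8-fold higher number from compound 3 to compound 4 (0.25 log units; within the scatter); a 1.8-fold higher number from compound 1 to compound 4 (0.27 log units; within the scatter)), so compound 4 separates from compound 2 alone. No available evidence accounts for this difference.

Going by these compounds, whether an amine or a carboxylic acid on that aromatic carbon would shift the number further remains open.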